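The source may hold more compounds than are shown below. What is called first, only, known or untested is meant among the compounds shown, and "the series" means these compounds.

Compound 1 `CCC(c1ccc(Br)cc1)(C(C)O)n1ncc2c(NS(C)(=O)=O)cccc21`: 3.6 h
Compound 2 `CCC(O)C(CC)(c1ccc(C(F)(F)F)cc1)n1ncc2c(NS(C)(=O)=O)cccc21`: 5.3 h

In an ADME assay for metabolic stability, with Rattus norvegicus as the target (on this read-out higher numbers stand for a longer-lived compound and lower numbers for a shorter-lived compound), compound 2 gives 5.3 h and compound 1 gives 3.6 h. These two numbers lie within the usual scatter of repeated measurements, so they cannot be told apart. Among the compounds with values here, compound 2 therefore stands level with the only other measured compound.

Compound 3 `CCC(c1ccc(C(F)(F)F)cc1)(C(O)C(F)F)n1ncc2c(NS(C)(=O)=O)cccc21` has not yet been measured. It differs from compound 2 in one place: difluoromethyl in place of ethyl on a saturated chain carbon bound to an oxygen on a saturated carbon and a saturated chain carbon. In words, this is difluoromethyl in place of ethyl on a saturated chain carbon bound to an oxygen on a saturated carbon and a saturated chain carbon. Cut one bond further out, the same difference reads 1-hydroxypropyl to 2,2-difluoro-1-hydroxyethyl.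

Within the data shown here, compound 1 and compound 2 differ in more than one place, and no measured pair shows this single change, so the data offer no direct guide to its size. The expected step, a 1.1-fold lower number from compound 2 to compound 3 (0.03 log units; within the scatter), is estimated to stay within the scatter, with neither direction favoured. The estimate therefore starts from compound 2 at 5.3 h, the nearest measured structure. In this assay, compound 3 is expected at 5 h, with an estimated range from 2.3 h to 10 h.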

Compound 3, half-life: 9.9 h
Estimate against measurement, compound 3: 2.0-fold (0.30 log units) below, and the stated range covers the measured number.
By their numbers in this assay, from the lowest: compounds 1, 2 and 3 (each within the scatter of the next, the first and the last beyond it).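

Within the data shown here, this is the first reading of a single change at this place. In this assay the change of difluoromethyl in place of ethyl, which cut one bond further out reads 1-hydroxypropyl to 2,2-difluoro-1-hydroxyethyl, gives a 1.9-fold higher number from compound 2 to compound 3 (0.27 log units; within the scatter) and so leaves the two compounds indistinguishable, even though two carbon atoms leave and one carbon with two fluorine atoms enters. This position on a saturated chain carbon therefore takes the swap with no measurable loss of half-life and no gain that can be claimed, while nothing measured here bears on why the reading came out this way.

The compounds shown leave open whether the fluorine atoms or the shorter chain matters more for this reading, and a plain methyl or a trifluoromethyl at the same place would help to separate the two. On these data alone, it also remains open how a longer chain such as propyl, or a polar group such as an amine on that chain, would read, and whether any group at this place can move the half-life beyond the usual scatter.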